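Chloro for Methyl: Expected Solubility of Compound 4

This account rests on a few compounds, and the source may have more. Where it says the series, first, only, none or still open, it means among the compounds named here.

Compound 1 `Cc1c(-c2c3c(N)n[nH]c(=O)c3nn2-c2ccc(NC(=O)/C=C/CN(C)C)cc2)oc2ccc(Cl)cc12` and compound 2 `Cc1ccc2oc(-c3c4c(N)n[nH]c(=O)c4nn3-c3ccc(NC(=O)/C=C/CN(C)C)cc3)c(C)c2c1` share one large core, while compound 3 `CCOC(=O)c1oc2ccc(C)cc2c1C` is a small ethyl ester; how the core of compound 3 differs from that of compound 2 is not broken down here. In a physicochemical assay for solubility, read by nephelometry, in phosphate buffer, measured as kinetic solubility, at pH 7.4 (on this read-out higher numbers stand for higher solubility and lower numbers for lower solubility), compound 2 gives 50000 nM, and compound 1 gives 200000 nM. The change between them is chloro in place of methyl on an aromatic carbon, a step of a 4.0-fold higher number from compound 2 to compound 1 (0.60 log units; beyond the scatter). In this assay compound 3 gives 200000 nM, level with compound 1. Compound 4 `CCOC(=O)c1oc2ccc(Cl)cc2c1C` differs from compound 3 by chloro in place of methyl on an aromatic carbon, the same change in the same place. Because compound 3 already gives 200000 nM, the step expected here is no change at the digits printed from compound 3 to compound 4 (within the scatter), smaller than the earlier one, though a single earlier example is thin support. Compound 4 is expected to give about 200000 nM, between 70000 nM and 400000 nM.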

Compound 4, solubility: 200000 nM
The estimate for compound 4 equals the measured number at the digits printed; measured number inside the range.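

In this assay, chloro in place of methyl on an aromatic carbon gives no change at the digits printed from compound 3 to compound 4 (within the scatter), while the same change on the larger core gave a 4.0-fold higher number from compound 2 to compound 1 (0.60 log units; beyond the scatter). Among the compounds shown here, the change therefore did not carry over at the same size, since only one of these two cores shows a step beyond the scatter, but two pairs are too few to set a rule for the series. Nothing available here explains why the two steps differ.

The compounds shown leave open how a fluoro group or a methoxy group on that aromatic carbon would read in this assay. They also leave open what a carboxylic acid or an amine in place of the ethyl ester would give.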